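A chloro swap in a series stuck at its limit

The source may report more compounds than this note shows. Statements on the series, on what has been measured and on what is new or still open speak of the compounds shown alone.

Compound 1 `C=C(C)C(=O)c1ccc(OC(C)C(=O)O)cc1C` is the starting point, and it is judged in a functional assay on HL-60 cells (Homo sapiens) for antiproliferative activity, with a stated time of 72 h; on this read-out lower numbers stand for stronger inhibition of growth and higher numbers for weaker inhibition of growth. In this assay compound 1 gives > 60000 nM, which is a limit of the assay and not a number. Compound 2 `C=C(CC)C(=O)c1ccc(OC(C)C(=O)O)cc1C` gives > 60000 nM, also a limit. Compound 3 `C=C(C)C(=O)c1ccc(OCC(=O)O)cc1C` gives > 60000 nM, again a limit. Among the compounds with values here, the whole series so far therefore shows (the limit of > 60000 nM in this assay, at which 3 of the 3 values shown sit).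

Compound 4 `C=C(C)C(=O)c1ccc(OC(C)C(=O)O)cc1Cl` differs from compound 1 in one place: chloro in place of methyl on an aromatic carbon. Chloro takes the place of methyl on an aromatic carbon, ortho to a (1-methylethenyl)carbonyl group and meta to a 1-carboxyethoxy group. Two measured steps change other parts of the molecule, and neither has a readable size: one is a step that the two limits leave unreadable from compound 1 to compound 2, and the other is a step that the two limits leave unreadable from compound 1 to compound 3. They give no sign of any growth inhibition to build on, so no real shift is expected. The expected step is a number no higher from compound 1 to compound 4 (the limit leaves the size open), which means none beyond the scatter. Compound 4 is estimated at 60000 nM, with an expected range of 25000 nM to 100000 nM.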

Compound 4, concentration for 50% growth inhibition: > 60000 nM
Compound 4 ended at the assay's limit; the forecaster's own chance of this, stated with the estimate: 80%; the middle value lies on the limit itself.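

Compound 4 gives > 60000 nM in this assay, a limit of the assay and not a number, so no step from compound 1 to compound 4 can be read: the limit of > 60000 nM in this assay, at which 4 of the 4 values shown sit.

The compounds shown leave open how these four compare in this assay, and whether any change to the shared core brings real growth inhibition.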